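Chloro substitution on a quinoline-free shared core, repeated

The source may hold more compounds than are shown below. What is called first, only, known or untested is meant among the compounds shown, and "the series" means these compounds.

Compound 1, `FC(F)(F)c1ccc(/C=C\c2cc3ccccc3nc2Cl)cc1`, is the reference point. In a functional assay on MDA-MB-231 cells (Homo sapiens) for antiproliferative activity, read by sulforhodamine B assay, with a stated time of 72 h (a lower number here means a stronger inhibitor, a higher number a weaker inhibitor), compound 1 gives 5360 nM. Compound 2, `FC(F)(F)c1ccc(/C=C\c2cc3ccc(Cl)cc3nc2Cl)cc1`, carries one change relative to compound 1: chloro in place of hydrogen on an aromatic carbon. This change produced a 2.5-fold higher number from compound 1 to compound 2 (0.40 log units; beyond the scatter), so that compound 2 gives 13600 nM in this assay.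

Compound 3, `FC(F)(F)c1cc(/C=C\c2cc3ccccc3nc2Cl)cc(C(F)(F)F)c1`, shares the general layout of compound 1 but its core is not the same; the difference between the two cores is not broken down here. In this assay compound 3 gives 10100 nM. The values of compound 3 and compound 2 are within the scatter of each other, as are those of compound 3 and compound 1, so no ordering among the three is claimed.

Compound 4, `FC(F)(F)c1cc(/C=C\c2cc3ccc(Cl)cc3nc2Cl)cc(C(F)(F)F)c1`, has not yet been measured. Relative to compound 3 it carries chloro in place of hydrogen on an aromatic carbon. This is the same change that separates compound 2 from compound 1, made on the same kind of place of the shared core. Among the compounds with values here, with only one earlier example of the change, the expectation rests on that single step: the expected step is a 2.2-fold higher number from compound 3 to compound 4 (0.34 log units; beyond the scatter), set beside the measured 2.5-fold higher number from compound 1 to compound 2 (0.40 log units; beyond the scatter). Compound 4 is therefore expected to give 22000 nM in this assay. The estimate for compound 4 is expected to lie between 9000 nM and 55000 nM, the width reflecting that one prior step cannot show whether the change carries over to a different core.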

Compound 4, half-maximal inhibitory concentration: > 50000 nM
Compound 4: a limit, no number; the forecaster's own chance of this, stated with the estimate: 25%; at least 2.2-fold (0.35 log units) between middle value and limit.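

In this assay compound 4 gives > 50000 nM, which is a limit of the assay and not a number: the limit of > 50000 nM in this assay, at which 1 of the 4 values shown sits. Chloro in place of hydrogen on an aromatic carbon gives an at least 4.9-fold higher number from compound 3 to compound 4 (0.69 log units; beyond the scatter), while on the core of compound 1 the same change gave a 2.5-fold higher number from compound 1 to compound 2 (0.40 log units; beyond the scatter), so on both cores in this series the change goes toward weaker inhibition, beyond the scatter each time. This shows that the direction of the change carried over from one core to the other, but it does not show whether the size of the step carried over, and two cores are too few to support a general rule: the same change on two cores in this assay, a 2.5-fold higher number (0.40 log units; beyond the scatter) from compound 1 to compound 2 and an at least 4.9-fold higher number (0.69 log units; beyond the scatter) from compound 3 to compound 4; the limit leaves it open whether they differ.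

The compounds shown have only hydrogen or chloro at this place on the aromatic ring, leaving open whether fluoro, a methoxy group or an amine there would also move the number toward weaker inhibition. They also leave open whether the chloro step would keep its direction on a core in which a nitrile or a carboxylic acid stands in place of trifluoromethyl.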